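This account rests on a few compounds, and the source may have more. Where it says the series, first, only, none or still open, it means among the compounds named here.

Series notes. Compound 1 `O=C1C(Nc2ccc(I)cc2)=CC(=O)c2c1nc1n2[C@H]2OC[C@@H](O)[C@H]2OC1` and compound 2 `O=C1C(Nc2ccc(C(F)(F)F)cc2)=CC(=O)c2c1nc1n2[C@H]2OC[C@@H](O)[C@H]2OC1` share one core and differ only at the aromatic carbon of the anilino ring. In a functional assay on ECa-109 cells for inhibition, with ECa-109 cell line (Homo sapiens) as the target, read by sulforhodamine B assay (on this read-out higher numbers stand for weaker inhibition and lower numbers for stronger inhibition), compound 1 gives 2530 nM, and compound 2 gives 2250 nM. For the measured compounds named here, the step of a 1.1-fold lower number from compound 1 to compound 2 (0.05 log units; within the scatter) is the only measured step in the set, and it does not separate the two compounds beyond the scatter. Compound 2 therefore stands at the lower of the two numbers with compound 1 close by, and the two cannot be ordered.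

Compound 3 `O=C1C(NCc2ccccc2)=CC(=O)c2c1nc1n2[C@H]2OC[C@@H](O)[C@H]2OC1` is not yet measured in this assay. It differs from compound 2 by benzyl in place of 4-(trifluoromethyl)phenyl on an amine nitrogen. Going by the values given here, no measured step bears directly on this change: the one step on record, from compound 1 to compound 2, swaps one group for another on the aromatic ring while keeping the aryl attached to the nitrogen, whereas here the aryl itself is replaced. Compound 3 is therefore expected to land near compound 2, with a wide range, the expected step being a 1.6-fold higher number from compound 2 to compound 3 (0.19 log units; within the scatter). Compound 3 is estimated at 3500 nM, between 900 nM and 14000 nM.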

Compound 3, half-maximal inhibitory concentration: > 8000 nM
Compound 3: no number, only a limit; the forecaster's own chance of this, stated with the estimate: 10%; middle value at least 2.2-fold (0.35 log units) from the limit.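

For the compounds shown here, the amine nitrogen is the first place where a change separates compounds beyond the scatter: in this assay, benzyl in place of 4-(trifluoromethyl)phenyl gives an at least 3.5-fold higher number from compound 2 to compound 3 (0.55 log units; beyond the scatter), and benzyl in place of 4-iodophenyl gives an at least 3.1-fold higher number from compound 1 to compound 3 (0.49 log units; beyond the scatter). The reading for compound 3 is a limit and not a number: the limit of > 8000 nM in this assay, at which 1 of the 3 values shown sits. Compound 1 and compound 2 stay within the scatter of each other, so across these three compounds the exchange of the whole group on the amine nitrogen registers, whereas the exchange of iodo for trifluoromethyl on the aromatic carbon does not.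

The benzyl exchange changes two things at once, since the ring is no longer bonded directly to the amine nitrogen and it also carries neither iodo nor trifluoromethyl, and the compounds shown cannot separate these two changes. From the compounds shown here alone, it remains open whether an unsubstituted phenyl, a 4-(trifluoromethyl)benzyl or a longer chain such as phenethyl on the amine nitrogen would read with compound 1 and compound 2 or with compound 3.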